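The source may report more compounds than this note shows. Statements on the series, on what has been measured and on what is new or still open speak of the compounds shown alone.

Measured in a functional assay on LOX IMVI cells (Homo sapiens) for inhibition, read by sulforhodamine B assay, with a stated time of 48 h; on this read-out lower numbers stand for stronger inhibition of growth and higher numbers for weaker inhibition of growth:

Compound 1 `COc1ccc(-c2ccc(-c3ccc(C(=N)N)cc3)s2)cc1` gives 198 nM.
Compound 2 `N=C(N)c1ccc(-c2ccc(-c3cc(Cl)cc(Cl)c3)s2)cc1` gives 155 nM.

Of these two numbers, compound 1 has the higher one, and its nearest neighbour is compound 2; the two values lie within the usual scatter of each other, so no order between them can be read from the data. Compound 3 `N=C(N)c1ccc(-c2ccc(-c3ccc(F)cc3)s2)cc1` has not yet been measured in this assay. It differs from compound 1 in a single place, on the ring that carries the methoxy group of compound 1: fluoro in place of methoxy on an aromatic carbon. Among the measured compounds shown here, no pair of measured compounds shows what this change does here, so any expectation rests on compound 1 alone and on the fact that compound 1 and compound 2 stay close to each other despite carrying quite different groups on that ring. A step no larger than the scatter is expected, with a slight lean towards a higher number, as in the expected 1.3-fold higher number from compound 1 to compound 3 (0.10 log units; within the scatter). Compound 3 is therefore expected to give about 250 nM in this assay, with a range from 90 nM to 700 nM.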

Compound 3, concentration for 50% growth inhibition: 164 nM
For compound 3 the middle estimate is 1.5-fold (0.18 log units) above the measured one; measured number inside the range.
By their numbers in this assay, from the lowest: compounds 2, 3 and 1 (each within the scatter of the next).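

In this assay, among the compounds shown here, the exchange of methoxy for fluoro on this aromatic carbon, para to a large group, gives a 1.2-fold lower number from compound 1 to compound 3 (0.08 log units; within the scatter) and so provides the first direct reading of a single change at this position. Within this pair, replacing the two heavy atoms of methoxy, including its one hydrogen-bond acceptor, with the single fluorine atom leaves no difference that this read-out can separate from the scatter. No independent measurement is available to explain why the two groups give such similar results.

As far as these compounds go, how an amine or a carboxylic acid on this aromatic carbon, or a longer chain such as butoxy, would read in this assay remains open, so the limits of what this position accepts are not yet defined. This one step also leaves open whether fluoro in place of methoxy would give a similarly small step at another place on the ring or on a different core.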